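The source may report more compounds than this note shows. Statements on the series, on what has been measured and on what is new or still open speak of the compounds shown alone.

Compound 3 `COc1ccc(N2C(=O)N(Cc3c(F)cc(F)cc3Cl)c3ccccc3S2(=O)=O)cc1OC` gives 25.1 nM in an assay on isolated protein for displacement of a labelled ligand from Orexin/Hypocretin receptor type 1 (Homo sapiens), with a stated time of 90 min (a higher number here means a weaker inhibitor, a lower number a stronger inhibitor), the highest number of the three measured here. Compound 1 `COc1cc(F)c(CN2C(=O)N(c3ccc(OC)c(OC)c3)S(=O)(=O)c3ccccc32)c(F)c1` gives 2 nM and compound 2 `COc1ccc(N2C(=O)N(Cc3c(F)cccc3Cl)c3ccccc3S2(=O)=O)cc1OC` gives 7.94 nM in this assay; the steps of a 4.0-fold higher number from compound 1 to compound 2 (0.60 log units; beyond the scatter) and a 13-fold higher number from compound 1 to compound 3 (1.10 log units; beyond the scatter) show that the group on the saturated chain carbon bound to the ring nitrogen sets potency here. Compound 4 `COc1ccc(N2C(=O)N(Cc3ccccc3)c3ccccc3S2(=O)=O)cc1OC` carries phenyl in place of 2-chloro-4,6-difluorophenyl on a saturated chain carbon bound to an amide-type nitrogen in a ring. Among the compounds with values here, the step of a 3.2-fold higher number from compound 2 to compound 3 (0.50 log units; beyond the scatter) is the only one that touches a single atom of this ring, and it runs against the extra fluoro; removing it alone would be expected to lower the number, yet the two groups flanking the chain carbon leave as well, for which no measured step exists. The estimate for compound 4 is therefore 30 nM, between 8 nM and 120 nM, which means a 1.2-fold higher number from compound 3 to compound 4 (0.08 log units; within the scatter) is expected.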

Compound 4, inhibition constant: 2000 nM
Estimate against measurement, compound 4: 67-fold (1.82 log units) below; the whole stated range lies below it.
By their numbers in this assay, from the lowest: compound 1; then compound 2; then compound 3; then compound 4.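

In this assay, bare phenyl on this saturated chain carbon is far the poorest of the groups shown, and each substituted ring gives a much lower number (an 80-fold higher number from compound 3 to compound 4 (1.90 log units; beyond the scatter)) (a 250-fold higher number from compound 2 to compound 4 (2.40 log units; beyond the scatter)) (a 1000-fold higher number from compound 1 to compound 4 (3.00 log units; beyond the scatter)). These steps exceed every step among the substituted rings, so potency here depends chiefly on the ring carrying substituents at all, and the choice among those substituents matters less. No measurement at hand accounts for this loss.

Still open, going by these compounds, is whether a lone chloro or a lone fluoro on the phenyl recovers most of the potency. Also open, on these data alone, is how an amine or a carboxylic acid on this ring would fare.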